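A few compounds are considered here, and "the series" means these few. Any claim that something is new, unique, unknown or untested is made for them only; others in the source may bear on it.

Measured compounds:
Compound 1 `CC(C)CC1n2cncc2CN(Cc2ccc(OC(F)(F)F)cc2)S1(=O)=O`: 544 nM
Compound 2 `C[C@@H](c1ccc(Cl)cc1)N1Cc2cncn2C(CC2(C)COC2)S1(=O)=O`: 340 nM
Compound 3 `N#Cc1ccc(C2C(=O)N(Cc3ccccc3)Cc3cncn32)cc1`: 2 nM

All three were tested in an assay on cells for inhibition of cytochrome P450 11B1, mitochondrial (Homo sapiens); on this read-out lower numbers stand for stronger inhibition and higher numbers for weaker inhibition. Compound 2 has the second highest of the three numbers; compound 1 sits within the scatter of it, while compound 3 lies far lower, beyond the scatter. Compound 4 `C[C@@H](c1ccc(Cl)cc1)N1Cc2cncn2C(C[C@H](O)c2ccccc2)S1(=O)=O` has not yet been measured. It is compound 2 with one change: hydroxy(phenyl)methyl in place of 3-methyloxetan-3-yl on a saturated chain carbon bound to a saturated ring carbon. Among the measured compounds shown here, no measured pair shows this exact change, so the size of the step is uncertain. Compound 3 also bears a six-membered aromatic ring of carbon only, and its much lower number suggests an aromatic ring entering here could help. Compound 4 is therefore expected to give 150 nM, within a range from 30 nM to 800 nM. The expected step from compound 2 to compound 4 is a 2.3-fold lower number from compound 2 to compound 4 (0.36 log units; beyond the scatter), a modest move toward stronger inhibition that may not clear the scatter.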

Compound 4, half-maximal inhibitory concentration: 182 nM
For compound 4 the middle estimate is 1.2-fold (0.08 log units) below the measured one; the measured number falls inside the stated range.
By their numbers in this assay, from the lowest: compound 3; then compounds 4, 2 and 1 (each within the scatter of the next, the first and the last beyond it).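

Hydroxy(phenyl)methyl in place of 3-methyloxetan-3-yl makes the step of a 1.9-fold lower number from compound 2 to compound 4 (0.27 log units; within the scatter) at this position, on a saturated chain carbon bound to a saturated ring carbon. This position therefore accepts a six-membered aromatic ring of carbon only and a hydrogen-bond donor without a change that the scatter lets one read. Nothing available explains this result. Compound 4 brings in the hydroxy group and the phenyl ring together, leaving their separate contributions open. As far as these compounds go, how an amine or a carboxylic acid would fare at this position also remains open.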